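A few compounds are considered here, and "the series" means these few. Any claim that something is new, unique, unknown or untested is made for them only; others in the source may bear on it.

In a functional assay on SF-268 cells (Homo sapiens) for cytotoxicity, read by sulforhodamine B assay, with a stated time of 48 h, tested at 10 uM (on this read-out higher numbers stand for a weaker effect at the one concentration tested and lower numbers for a stronger effect), three compounds have been measured:

compound 1 `COc1cc(-c2cc(/C=C/C(=O)c3ccc(N)cc3)[nH]n2)cc(OC)c1OC` gives -55%
compound 2 `COc1ccc(C(=O)/C=C/c2cc(-c3cc(OC)c(OC)c(OC)c3)n[nH]2)cc1OC` gives -60%
compound 3 `COc1ccc(C(=O)/C=C/c2cc(-c3cc(OC)c(OC)c(OC)c3)n[nH]2)cc1` gives -35%

Compound 4 `COc1ccc(-c2cc(/C=C/C(=O)c3ccc(N)cc3)[nH]n2)cc1OC` is not yet measured. It differs from compound 1 by hydrogen in place of methoxy on an aromatic carbon. The same kind of change separates compound 2 from compound 3, (hydrogen in place of methoxy on an aromatic carbon), and there it gave a number 25 percentage points higher from compound 2 to compound 3 (beyond the scatter). The two places are not identical: in compound 1 the carbon is also meta to a methoxy group, so the change is the same kind rather than the same. The two cores differ by 4-aminophenyl in place of 3,4-dimethoxyphenyl on a carbonyl carbon, a change that gave a number 5 percentage points lower from compound 1 to compound 2 (within the scatter). Because of a number 25 percentage points higher from compound 2 to compound 3 (beyond the scatter) a step of similar size is expected from compound 1, a number 25 percentage points higher from compound 1 to compound 4 (beyond the scatter). Compound 4 is therefore estimated at -30%, with a range from -50% to -10%.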

Compound 4, a percentage reported as activity, at one concentration (the size of the read-out at that concentration, not a potency): -49%
Beside the measured number, compound 4's estimate is 19 percentage points above it, and the stated range covers the measured number.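

In this assay, putting hydrogen in place of methoxy on an aromatic carbon gives a number 6 percentage points higher from compound 1 to compound 4 (within the scatter). The same kind of change therefore does not carry over at the same size from one core to the other: the same change on two cores in this assay, a number 25 percentage points higher (beyond the scatter) from compound 2 to compound 3 and a number 6 percentage points higher (within the scatter) from compound 1 to compound 4, 19 percentage points apart, beyond the scatter of two such steps. This rests on a single pair for each core, and the two changes do not sit in identical places, so it does not show whether the core itself or the exact place accounts for the gap.

The compounds shown leave open how a hydroxyl group or an ethoxy group would behave at this place. They also leave open whether the change would give a large or a small step on any further core.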